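Ester, ether, and amine at one chain carbon

This account rests on a few compounds, and the source may have more. Where it says the series, first, only, none or still open, it means among the compounds named here.

Measured so far:
compound 1 `CCC(=O)OCc1c(F)c(N)c2c(=O)cc(-c3ccc(N)c(F)c3)oc2c1F`: 130 nM
compound 2 `CCCOCc1c(F)c(N)c2c(=O)cc(-c3ccc(N)c(F)c3)oc2c1F`: 1200 nM

In a functional assay on MCF7 cells (Homo sapiens) for cytotoxicity, read by neutral red uptake, with a stated time of 3 days (a lower number here means a stronger inhibitor, a higher number a weaker inhibitor), compound 2 gives 1200 nM, the higher of the two numbers, with compound 1 as its nearest neighbour at 130 nM. Compound 3 `NCc1c(F)c(N)c2c(=O)cc(-c3ccc(N)c(F)c3)oc2c1F` carries amino in place of propoxy on a saturated chain carbon bound to an aromatic carbon. Among the compounds with values here, only one measured step touches this position, a 9.2-fold higher number from compound 1 to compound 2 (0.97 log units; beyond the scatter), and it concerns a different exchange, so it gives no firm guide. Compound 3 is therefore expected near compound 2, with a wide range, the step of a 1.5-fold lower number from compound 2 to compound 3 (0.18 log units; within the scatter) being an estimate only. The value expected for compound 3 is 800 nM, between 150 nM and 4000 nM.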

Compound 3, half-maximal inhibitory concentration: 26 nM
The estimate for compound 3 lay 31-fold (1.49 log units) above the measured number; measured number below the stated range.
By their numbers in this assay, from the lowest: compound 3; then compound 1; then compound 2.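

In this assay, the amino group gives the lowest number at this chain carbon, with a 46-fold lower number from compound 2 to compound 3 (1.66 log units; beyond the scatter) and a 5.0-fold lower number from compound 1 to compound 3 (0.70 log units; beyond the scatter). The position therefore spans a wider range than the exchange of ester for ether had revealed, and compound 3 now stands beyond the scatter from both other compounds. Nothing measured here explains this result.

The compounds shown leave open whether a methylamino or dimethylamino group would keep this low number. They also leave open how a hydroxyl or an acetamide at the same carbon would compare.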